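The source may hold more compounds than are shown below. What is called first, only, known or untested is meant among the compounds shown, and "the series" means these compounds.

In a functional assay on HL-60 cells (Homo sapiens) for cytotoxicity, read by MTT assay (a higher number here means a weaker inhibitor, a lower number a stronger inhibitor), compound 1 (`CC(=O)c1ccc(S(=O)(=O)NC(C2=CC(=O)c3c(O)ccc(O)c3C2=O)C(C)C)cc1`) gives 110 nM and compound 2 (`CC(NS(=O)(=O)c1ccccc1Br)C1=CC(=O)c2c(O)ccc(O)c2C1=O`) gives 120 nM and so stands level with it, within the scatter. The change to compound 3 (`CC(=O)c1ccc(S(=O)(=O)NC(C)C2=CC(=O)c3c(O)ccc(O)c3C2=O)cc1`) reads 4-acetylphenyl in place of 2-bromophenyl on a sulfonyl sulfur and puts 4-acetylphenyl in place of 2-bromophenyl on a sulfonyl sulfur. Among the measured compounds shown here, no measured step isolates this swap, so in this assay no step beyond the scatter is expected, and neither direction is favoured. The estimated 1.1-fold higher number from compound 2 to compound 3 (0.03 log units; within the scatter) is accordingly small. Compound 3 is expected at 130 nM within a range of 45 nM to 380 nM on this estimate.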

Compound 3, half-maximal inhibitory concentration: 260 nM
The estimate for compound 3 lay 2.0-fold (0.30 log units) below the measured number; the measured number falls inside the stated range.
By their numbers in this assay, from the lowest: compounds 1 and 2 (each within the scatter of the next); then compound 3.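

In this assay, 4-acetylphenyl in place of 2-bromophenyl on the sulfonyl sulfur gives a 2.2-fold higher number from compound 2 to compound 3 (0.34 log units; beyond the scatter), and methyl in place of isopropyl on the saturated chain carbon gives a 2.4-fold higher number from compound 1 to compound 3 (0.37 log units; beyond the scatter). Each place therefore registers when changed alone, which the level values of compound 1 and compound 2, differing in two places, could not show. Nothing available explains either step. The compounds shown leave open how a carboxylic acid in place of the acetyl on the phenyl ring would read. They also leave open how a longer chain in place of the isopropyl would read.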